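Methoxy added on the carbonyl-side ring of a pyrazole chalcone

The source may report more compounds than this note shows. Statements on the series, on what has been measured and on what is new or still open speak of the compounds shown alone.

Measured compounds:
compound 1 `COc1cc(-c2cc(/C=C/C(=O)c3ccc(Cl)c(Cl)c3)[nH]n2)cc(OC)c1OC`: 14500 nM
compound 2 `COc1ccc(-c2cc(/C=C/C(=O)c3cc(OC)c(OC)c(OC)c3)[nH]n2)cc1OC`: 2020 nM
compound 3 `COc1ccc(C(=O)/C=C/c2cc(-c3cc(OC)c(OC)c(OC)c3)n[nH]2)cc1OC`: 1520 nM

The read-out is a functional assay on NCI-H322M cells (Homo sapiens) for inhibition, read by sulforhodamine B assay, with a stated time of 48 h; on this read-out lower numbers stand for stronger inhibition of growth and higher numbers for weaker inhibition of growth. Compound 3 gives the lowest of the three numbers, 1520 nM; compound 2 sits nearest with 2020 nM, and the two values lie within the scatter of each other, so no order between them is claimed. Going by the values given here, compound 1 gives 14500 nM, and the only single-place step in the set is a 9.5-fold lower number from compound 1 to compound 3 (0.98 log units; beyond the scatter). The change in that step is 3,4-dimethoxyphenyl in place of 3,4-dichlorophenyl on a carbonyl carbon.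

Compound 4 `COc1cc(C(=O)/C=C/c2cc(-c3cc(OC)c(OC)c(OC)c3)n[nH]2)cc(OC)c1OC` differs from compound 3 by methoxy in place of hydrogen on an aromatic carbon. Among the compounds with values here, no measured step concerns a methoxy versus a hydrogen on this ring, so the one step available does not bear on the change directly. The values of compound 2 and compound 3 show that rings with different methoxy counts on either side give numbers within the scatter of one another. Compound 4 is therefore expected to give 1500 nM, in a range from 500 nM to 4500 nM. The expected step is a 1.0-fold lower number from compound 3 to compound 4 (0.01 log units; within the scatter), not beyond the scatter.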

Compound 4, concentration for 50% growth inhibition: 2000 nM
The estimate for compound 4 lay 1.3-fold (0.12 log units) below the measured number; low and high end bracket the measured number.
By their numbers in this assay, from the lowest: compounds 3, 4 and 2 (each within the scatter of the next); then compound 1.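

In this assay, methoxy in place of hydrogen on the carbonyl-side ring gives a 1.3-fold higher number from compound 3 to compound 4 (0.12 log units; within the scatter) and the same replacement on the other aryl ring gives a 1.0-fold lower number from compound 2 to compound 4 (0.00 log units; within the scatter), so both steps lie within the scatter and neither ring shows a readable change from this replacement. Among the compounds shown, the position ortho to a methoxy group therefore accepts methoxy or hydrogen without a separable difference on this read-out. No independent measurement offers an explanation for this result.

The compounds shown leave open whether a hydroxyl, an amine or a carboxylic acid at this position would stay within the scatter of compound 4. They also leave open whether a longer chain such as ethoxy or propoxy in place of methoxy would move the number beyond the scatter.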